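Propanoyl to vinylcarbonyl: expected change in the ester series

This account rests on a few compounds, and the source may have more. Where it says the series, first, only, none or still open, it means among the compounds named here.

Measured in a functional assay on HepG2 cells (Homo sapiens) for cytotoxicity, read by MTT assay; on this read-out lower numbers stand for stronger inhibition and higher numbers for weaker inhibition:
- compound 1 `C=CCOc1cc(/C=C/C(=O)c2ccc(OC)c3c2OC(C)(C)C=C3)ccc1OC`: > 10000 nM (a limit of the assay)
- compound 2 `CCC(=O)Oc1cc(/C=C/C(=O)c2ccc(OC)c3c2OC(C)(C)C=C3)ccc1OC`: 90 nM

Within the data shown here, compound 2, at 90 nM, gives the only actual number so far. Compound 1 stands at the limit of > 10000 nM in this assay, at which 1 of the 2 values shown sits.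

Compound 3 `C=CC(=O)Oc1cc(/C=C/C(=O)c2ccc(OC)c3c2OC(C)(C)C=C3)ccc1OC` differs from compound 2 in one place: vinyl in place of ethyl on a carbonyl carbon. In words, vinyl replaces ethyl on a carbonyl carbon, and the carbonyl stays.

Among the measured compounds shown here, only one measured step bears on this change: an at least 110-fold lower number from compound 1 to compound 2 (2.04 log units; beyond the scatter). That large step exchanged allyl for propanoyl on the oxygen, a wider change than the one made here, and it starts from a limit. It is weak guidance for the present change. In this assay a much smaller step is therefore expected, with no direction favoured and probably nothing beyond the scatter. The estimated step is a 1.1-fold higher number from compound 2 to compound 3 (0.05 log units; within the scatter). For compound 3 the estimated value is 100 nM, with an expected range of 30 nM to 350 nM.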

Compound 3, half-maximal inhibitory concentration: 160 nM
Estimate against measurement, compound 3: 1.6-fold (0.20 log units) below; measured number inside the range.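

In this assay, vinyl in place of ethyl on the carbonyl carbon gives a 1.8-fold higher number from compound 2 to compound 3 (0.25 log units; within the scatter), so in this pair the extra double bond outside aromatic rings does not move the read-out beyond the scatter. The second carbonyl-bearing group also separates clearly from allyl on the oxygen, with an at least 62-fold lower number from compound 1 to compound 3 (1.79 log units; beyond the scatter), and among the compounds shown, both propanoyl and vinylcarbonyl now stand apart from allyl. This step starts from a limit of the assay for compound 1, so its size is only a bound: the limit of > 10000 nM in this assay, at which 1 of the 3 values shown sits.

Still open, on these data alone, is whether the carbonyl itself is enough, which a shorter acetyl group or a longer butanoyl chain on the same oxygen would test. Also open, as far as these compounds go, is how a free hydroxyl or an amine at this place would read in this assay.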